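A few compounds are considered here, and "the series" means these few. Any claim that something is new, unique, unknown or untested is made for them only; others in the source may bear on it.

Compound 1 `O=C(O)Cc1nn(Cc2cn3cc(OCC4CC4)c(Cl)cc3n2)c2ccccc2c1=O`: 919 ug/mL
Compound 2 `CCC(C(=O)O)c1nn(Cc2cn3cc(OCC4CC4)c(Cl)cc3n2)c2ccccc2c1=O`: 359 ug/mL

Of the two compounds measured in a physicochemical assay for solubility, measured as thermodynamic solubility, at pH 7.4 (on this read-out lower numbers stand for lower solubility and higher numbers for higher solubility), compound 2 has the lower number, at 359 ug/mL. Compound 3 `C[C@H](C(=O)O)c1nn(Cc2cn3cc(OCC4CC4)c(Cl)cc3n2)c2ccccc2c1=O` carries 1-carboxyethyl in place of 1-carboxypropyl on an aromatic carbon. Going by the values given here, only one measured step bears on this change: a 2.6-fold lower number from compound 1 to compound 2 (0.41 log units; beyond the scatter). That modest step came with ethyl in place of hydrogen on the chain carbon, and the entering group in compound 3 is the smaller of the two. Going by compound 2 at 359 ug/mL and compound 1 at 919 ug/mL, a rise smaller than that measured step is expected in this assay. The expected step is a 1.5-fold higher number from compound 2 to compound 3 (0.19 log units; within the scatter). For compound 3 the estimate is 550 ug/mL, with an expected range of 300 ug/mL to 1000 ug/mL.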

Compound 3, solubility: 892 ug/mL
The estimate for compound 3 lay 1.6-fold (0.21 log units) below the measured number; the range from low to high includes it.
By their numbers in this assay, from the lowest: compound 2; then compounds 3 and 1 (each within the scatter of the next).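

In this assay the branch on the chain carbon proves to matter by its size: 1-carboxyethyl in place of 1-carboxypropyl on this aromatic carbon, next to the ring nitrogen, gives a 2.5-fold higher number from compound 2 to compound 3 (0.40 log units; beyond the scatter) and so reverses the step seen earlier. Methyl in place of hydrogen on the same chain carbon gives a 1.0-fold lower number from compound 1 to compound 3 (0.01 log units; within the scatter) and leaves compound 3 and compound 1 within the scatter of each other, so among these three compounds only the ethyl branch of compound 2 stands apart. Nothing shown here gives a measured reason for this difference between the methyl and ethyl branches.

The compounds shown leave open how the mirror-image form of 1-carboxyethyl would read. They also leave open whether an isopropyl branch, or an amine on the chain carbon, would read with compound 2 or with compound 3.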